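A few compounds are considered here, and "the series" means these few. Any claim that something is new, unique, unknown or untested is made for them only; others in the source may bear on it.

Compound 1 `CC(C)CN1C(=O)C=C(Cl)C1(O)c1ccccc1`: 262 nM
Compound 2 `CC(C)CN1C(=O)C=C(Cl)C1(O)c1ccc(Cl)cc1`: 242 nM

Among the compounds with values here, in a functional assay on AGS cells (Homo sapiens) for antiproliferative activity, read by MTT assay, with a stated time of 3 days (a lower number here means a stronger inhibitor, a higher number a weaker inhibitor), compound 1 gives 262 nM, and its only measured neighbour, compound 2, gives 242 nM. The two cannot be separated, so compound 1 stands level with compound 2 rather than at either end of a range. The next compound is compound 3 `O=C1C=C(Cl)C(O)(c2ccccc2)N1Cc1ccccc1`, not yet measured. The change is phenyl in place of isopropyl on a saturated chain carbon bound to an amide-type nitrogen in a ring, which also reads as isobutyl to benzyl.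

Within the data shown here, the only measured step is a 1.1-fold lower number from compound 1 to compound 2 (0.03 log units; within the scatter). It comes from chloro in place of hydrogen on an aromatic carbon, a different change in a different place, so it bears on compound 3 only weakly. Among the measured compounds shown here, no measured step covers the group on the nitrogen, which leaves the direction open and the range wide. The expected step is a 1.2-fold lower number from compound 1 to compound 3 (0.08 log units; within the scatter), which means no firm shift beyond the scatter is expected in this assay. For compound 3 the estimate is 220 nM, with an expected range of 70 nM to 700 nM.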

Compound 3, half-maximal inhibitory concentration: 53 nM
Beside the measured number, compound 3's estimate is 4.2-fold (0.62 log units) above it; the whole stated range lies above it.
By their numbers in this assay, from the lowest: compound 3; then compounds 2 and 1 (each within the scatter of the next).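

In this assay, within the data shown here, the group on the nitrogen is the first place where a single change moves the number beyond the scatter: isobutyl to benzyl gives a 4.9-fold lower number from compound 1 to compound 3 (0.69 log units; beyond the scatter), whereas the chloro change gave only a 1.1-fold lower number from compound 1 to compound 2 (0.03 log units; within the scatter). The position on a saturated chain carbon bound to an amide-type nitrogen in a ring therefore responds to phenyl in place of isopropyl, a swap that brings in one six-membered aromatic ring of carbon only where no ring stood before, and compound 3 now stands lowest of the three compounds at 53 nM. Nothing at hand accounts for this step, so it stands as an observation on these compounds alone.

A cyclohexyl group in the same place would separate the aromatic ring from the larger count of heavy atoms, and a longer chain such as phenethyl would test how far the ring can sit from the nitrogen. From the compounds shown here alone, it also remains open whether a chloro on the aromatic ring of compound 3 would stay within the scatter, as it does on the aromatic ring of compound 1, now that benzyl replaces isobutyl on the nitrogen.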